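Swapping a Cyclohexyl Amide for a Cyanophenyl Amide

The source may report more compounds than this note shows. Statements on the series, on what has been measured and on what is new or still open speak of the compounds shown alone.

Measured so far:
compound 1 `CC(C)OC(=O)C1=CN(C(=O)C2CCCCC2)CC(C)(C)c2cc(C#N)[nH]c21` gives 124%
compound 2 `CC(C)OC(=O)C1CN(C(=O)c2ccc(F)cc2)CC(C)(C)c2cc(C#N)[nH]c21` gives 85%
compound 3 `CC(C)OC(=O)C1CN(C(=O)C2CCOCC2)CC(C)(C)c2cc(C#N)[nH]c21` gives 112%

In an assay on HEK293 cells for agonist activity at Bile acid receptor (Homo sapiens), read by a luciferase reporter (a lower number here means a smaller maximal response, a higher number a larger maximal response), compound 1 stands highest of the three numbers; compound 3 is nearest to it and compound 2 furthest, and both gaps lie beyond the scatter. Compound 4 `CC(C)OC(=O)C1=CN(C(=O)c2ccc(C#N)cc2)CC(C)(C)c2cc(C#N)[nH]c21` has not yet been measured. It differs from compound 1 in a single place: 4-cyanophenyl in place of cyclohexyl on a carbonyl carbon. Going by the values given here, only one measured step touches the same place, the change a number 27 percentage points higher from compound 2 to compound 3 (beyond the scatter), in which a six-membered non-aromatic ring replaced a six-membered aromatic ring on the carbonyl carbon and the maximal response rose by a modest amount. The change leading to compound 4 runs the opposite way, from a non-aromatic ring to an aromatic one, so a modest fall is expected in this assay, a number 24 percentage points lower from compound 1 to compound 4 (beyond the scatter). Compound 4 is therefore estimated at 100%, with a likely range from 75% to 125%.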

Compound 4, largest response reached (reported as efficacy), in percent of the reference or control that the assay uses: 116%
Estimate against measurement, compound 4: 16 percentage points below, within the range that was stated.
By their numbers in this assay, from the lowest: compound 2; then compounds 3, 4 and 1 (each within the scatter of the next, the first and the last beyond it).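

In this assay, putting 4-cyanophenyl in place of cyclohexyl on the carbonyl carbon gives a number 8 percentage points lower from compound 1 to compound 4 (within the scatter) and so leaves the two compounds indistinguishable in maximal response. On the core of compound 1, then, an aromatic ring at this place can give a response that matches the cyclohexyl compound, something a number 27 percentage points higher from compound 2 to compound 3 (beyond the scatter) alone might have made seem doubtful. That earlier step involves different groups on a different core, so the two steps describe separate pairs and do not make a general rule. Nothing available here gives a reason for this result.

As far as these compounds go, it remains open whether the nitrile itself matters, since a plain phenyl group on the same core would be needed to show this. From the compounds shown here alone, whether a ring carrying an amine or a carboxylic acid would fit at this place also remains unknown.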